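A few compounds are considered here, and "the series" means these few. Any claim that something is new, unique, unknown or untested is made for them only; others in the source may bear on it.

Working notes on the series. In an ADME assay on microsomes from liver (Mus musculus) for metabolic stability, read by LC-MS, using NADPH, tested at 1 uM (a higher number here means that the compound lasts longer, a lower number that the compound disappears faster), compound 1 `Nc1nc(-c2cccc(C(F)(F)F)c2)c(C(=O)c2ccccc2Cl)s1` gives 0.0483 h and compound 2 `Nc1nc(-c2cc(Br)cc(C(F)(F)F)c2)c(C(=O)c2ccccc2Cl)s1` gives 0.0867 h. Among the compounds with values here, these two values lie within the scatter of each other, so compound 2 cannot be separated from compound 1 on the numbers so far.

Compound 3 `Nc1nc(-c2cc(C(F)(F)F)cc(C(F)(F)F)c2)c(C(=O)c2ccccc2Cl)s1` differs from compound 2 by a single change: trifluoromethyl in place of bromo on an aromatic carbon. This places trifluoromethyl in place of bromo on an aromatic carbon of the six-membered aromatic ring of carbon only, meta to a trifluoromethyl group.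

Within the data shown here, one measured step bears on this carbon: a 1.8-fold higher number from compound 1 to compound 2 (0.25 log units; within the scatter), which is bromo in place of hydrogen. Among the measured compounds shown here, that step stays within the scatter, and it is the only guide, since no measured compound yet carries a second trifluoromethyl group. No shift beyond the scatter is therefore expected in this assay, and no direction is favoured with any confidence. The estimated step is a 1.1-fold lower number from compound 2 to compound 3 (0.03 log units; within the scatter). For compound 3 the expected half-life is 0.08 h, with an estimated range of 0.04 h to 0.16 h.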

Compound 3, half-life: 0.123 h
Estimate against measurement, compound 3: 1.5-fold (0.19 log units) below, and the stated range covers the measured number.
By their numbers in this assay, from the lowest: compounds 1, 2 and 3 (each within the scatter of the next, the first and the last beyond it).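

In this assay, this position on the six-membered aromatic ring of carbon only now gives its first step beyond the scatter, though a modest one: trifluoromethyl in place of hydrogen (a 2.5-fold higher number from compound 1 to compound 3 (0.41 log units; beyond the scatter)). Bromo in place of hydrogen stayed within the scatter, and the exchange of bromo for trifluoromethyl does too (a 1.4-fold higher number from compound 2 to compound 3 (0.15 log units; within the scatter)), so the two groups cannot be separated at this place, even though the entering group has 4 heavy atoms and the leaving group has 1. Nothing available here bears on what lies behind these steps.

On these data alone, what an amine, a nitrile or a carboxylic acid at this position would give remains open, and with only one hydrogen, one bromo and one trifluoromethyl example, no trend with the group at this place can be drawn. Also open, as far as these compounds go, is whether the step from hydrogen to trifluoromethyl would hold without the trifluoromethyl group already on the ring, or with a different group on the carbonyl side of the shared core.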